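The compounds below may be only part of what the source reports. "The series", "measured", "known", "first", "only" and "open" are said of these compounds alone.

Values in a functional assay on K562 cells (Homo sapiens) for inhibition, read by trypan blue exclusion, with a stated time of 72 h; a lower number here means a stronger inhibitor, a higher number a weaker inhibitor:

- compound 1 `Cn1c(=O)c(S(=O)(=O)c2ccc(C(=O)O)cc2)cc2cnc(Nc3ccc4[nH]ccc4c3)nc21`: 5000 nM
- compound 2 `Cn1c(=O)c(S(=O)(=O)c2ccc(O)cc2)cc2cnc(Nc3ccc4[nH]ccc4c3)nc21`: 100 nM
- compound 3 `Cn1c(=O)c(S(=O)(=O)c2ccc(F)cc2[N+](=O)[O-])cc2cnc(Nc3ccc4[nH]ccc4c3)nc21`: 900 nM

Among these three numbers, compound 3 stands second highest, with a 5.6-fold lower number from compound 1 to compound 3 (0.74 log units; beyond the scatter) and a 9.0-fold higher number from compound 2 to compound 3 (0.95 log units; beyond the scatter). The next compound, compound 4 `Cn1c(=O)c(S(=O)(=O)Nc2ccc(F)cc2F)cc2cnc(Nc3ccc4[nH]ccc4c3)nc21`, carries (2,4-difluorophenyl)amino in place of 4-fluoro-2-nitrophenyl on a sulfonyl sulfur.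

Among the measured compounds shown here, no measured step makes this exchange, and no measured compound has an amino group on the sulfonyl sulfur. The steps above, together with a 50-fold lower number from compound 1 to compound 2 (1.70 log units; beyond the scatter), bear on it only indirectly, by showing how far changes in the group on that sulfur have moved the number. They give no direction for the new group, so no step beyond the scatter is expected in this assay, although a modest one either way remains possible. The expected change is a 1.5-fold lower number from compound 3 to compound 4 (0.18 log units; within the scatter). For compound 4 the estimated value is 600 nM, with an expected range of 120 nM to 3000 nM.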

Compound 4, half-maximal inhibitory concentration: 5000 nM
Compound 4: the middle estimate sits 8.3-fold (0.92 log units) below what was measured; the whole stated range lies below it.
By their numbers in this assay, from the lowest: compound 2; then compound 3; then compounds 1 and 4 (each within the scatter of the next).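

In this assay, placing (2,4-difluorophenyl)amino on the sulfonyl sulfur gives a 5.6-fold higher number from compound 3 to compound 4 (0.74 log units; beyond the scatter) and a 50-fold higher number from compound 2 to compound 4 (1.70 log units; beyond the scatter) for this change, the only one among these compounds that puts an amino group on that sulfur. The same group, compared with 4-carboxyphenyl, gives no change at the digits printed from compound 1 to compound 4 (within the scatter), so two groups that share little beyond an aromatic ring both stand at the high end of these numbers, well above the 4-hydroxyphenyl of compound 2. Nothing available explains this result.

The compounds shown do not separate the amino link from the 2,4-difluorophenyl ring, so it remains open which of the two carries the step from compound 3. A plain methylamino group on the sulfonyl sulfur, or a 2,4-difluorophenyl ring bonded directly to it, would begin to tell these apart.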